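Thienopyridine carboxamides: thiourea in place of the benzyl group

This account rests on a few compounds, and the source may have more. Where it says the series, first, only, none or still open, it means among the compounds named here.

Measured so far in a functional assay on HL-60 cells (Homo sapiens) for antiproliferative activity, with a stated time of 24 h; a higher number here means a weaker inhibitor, a lower number a stronger inhibitor:
compound 1 `NC(=O)c1c(NC(=O)c2ccccc2Cl)sc2c1CCN(Cc1ccc(Cl)cc1)C2`: 22500 nM
compound 2 `NC(=O)c1c(NC(=O)c2ccc(C(F)(F)F)cc2)sc2c1CCN(Cc1ccc(Cl)cc1Cl)C2`: 14900 nM

Both measured compounds share the same core and sit in the weak range of this assay. On the two numbers shown, compound 1 and compound 2 lie within the scatter of each other, so neither is separated from the other by a step that can be trusted. Within the data shown here, no pair that differs in one place has been measured, so no step of any size is known for this series.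

Compound 3 `NC(=O)c1c(NC(=O)c2ccccc2Cl)sc2c1CCN(C(=S)Nc1c(Cl)cccc1Cl)C2` is the next entry for this assay. Relative to compound 1 it differs as follows: a group of 11 heavy atoms (7 carbon, 1 nitrogen, 1 sulfur, 2 chlorine; one six-membered aromatic ring of carbon only) in place of a group of 8 heavy atoms (7 carbon, 1 chlorine; one six-membered aromatic ring of carbon only), on an amine nitrogen in a ring. The change sits on the amine nitrogen in a ring of the core, and it brings in a hydrogen-bond donor and acceptor where the 4-chlorobenzyl group had none. Nothing measured here says what a change of this kind does in this assay.

Among the measured compounds shown here, with no measured step to lean on, compound 3 is expected to remain close to compound 1, whose value is 22500 nM. The step that this estimate means, a 1.3-fold lower number from compound 1 to compound 3 (0.10 log units; within the scatter), is expected to be none beyond the scatter. Compound 3 is estimated at 18000 nM, with a range from 5000 nM to 60000 nM.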

Compound 3, half-maximal inhibitory concentration: 3950 nM
Compound 3: middle estimate off by 4.6-fold (0.66 log units), on the high side; the whole stated range lies above it.
By their numbers in this assay, from the lowest: compound 3; then compounds 2 and 1 (each within the scatter of the next).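

In this assay, the amine nitrogen in a ring of the core now has its first readable step: the thiourea group of compound 3 in place of 4-chlorobenzyl gives a 5.7-fold lower number from compound 1 to compound 3 (0.76 log units; beyond the scatter). This shows that the number in this assay responds to a change at this position, and that a larger group carrying a hydrogen-bond donor, a hydrogen-bond acceptor and a double bond outside aromatic rings is compatible with a lower number. No information bearing on the reason for this step is available.

The step comes from a single exchange of the whole group, so the thiourea link, its sulfur and the chlorines on the aromatic ring cannot be separated, and a urea with oxygen in place of sulfur, an amide link or an unsubstituted phenyl ring on the thiourea would help to divide it. The compounds shown also leave open whether the step carries over to other amide groups, such as the 4-trifluoromethylbenzoyl group of compound 2, and how a free ring amine would compare.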